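Ring swap on the ring amine: compound 3 to compound 4

A few compounds are considered here, and "the series" means these few. Any claim that something is new, unique, unknown or untested is made for them only; others in the source may bear on it.

Measured so far in an assay for inhibition of arginase-1 (Homo sapiens), read by colorimetric assay, with a stated time of 60 min, in the presence of a further agent that is not named here; a lower number here means a stronger inhibitor, a higher number a weaker inhibitor:
compound 1, `N[C@@]1(C(=O)O)CN(C[C@@H]2COCCN2)C[C@@H]1CCCB(O)O`, 10 nM
compound 2, `N[C@@]1(C(=O)O)CN(Cc2ncccc2F)C[C@@H]1CCCB(O)O`, 670 nM
compound 3, `N[C@@]1(C(=O)O)CN(Cc2ccncc2)C[C@@H]1CCCB(O)O`, 600 nM

Compound 3 stands second highest of the three numbers; its nearest neighbour is compound 2, with a 1.1-fold lower number from compound 2 to compound 3 (0.05 log units; within the scatter), and compound 1 lies far off, with a 60-fold higher number from compound 1 to compound 3 (1.78 log units; beyond the scatter).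

Compound 4, `N[C@@]1(C(=O)O)CN(C[C@H]2COCCN2)C[C@@H]1CCCB(O)O`, is the next case. The change is a group of 6 heavy atoms (4 carbon, 1 nitrogen, 1 oxygen; one six-membered non-aromatic ring with 2 hetero atoms) in place of a group of 6 heavy atoms (5 carbon, 1 nitrogen; one six-membered aromatic ring with 1 hetero atom), on a saturated chain carbon bound to an amine nitrogen in a ring. The entering ring matches the ring carried by compound 1 in atom count and ring type, but its one defined stereocentre is set differently.

Among the compounds with values here, two measured steps bear on this. The ring of compound 1 against the aromatic ring of compound 3 gave a 60-fold higher number from compound 1 to compound 3 (1.78 log units; beyond the scatter), and against the aromatic ring of compound 2 gave a 67-fold higher number from compound 1 to compound 2 (1.83 log units; beyond the scatter). Both point the same way: the saturated ring gives the markedly lower number. Within the data shown here, the altered stereocentre has no measured counterpart in this set, so how much of that gain carries over is open.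

A large downward step in this assay is therefore expected for compound 4, a 15-fold lower number from compound 3 to compound 4 (1.18 log units; beyond the scatter), though probably not all the way to the number of compound 1. The estimate for compound 4 is 40 nM, with a range from 8 nM to 200 nM.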

Compound 4, half-maximal inhibitory concentration: 19 nM
Beside the measured number, compound 4's estimate is 2.1-fold (0.32 log units) above it, within the range that was stated.
By their numbers in this assay, from the lowest: compounds 1 and 4 (each within the scatter of the next); then compounds 3 and 2 (each within the scatter of the next).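

In this assay, the six-membered non-aromatic ring on a saturated chain carbon bound to an amine nitrogen in a ring keeps its large gain over the aromatic rings with its stereocentre drawn either way, giving a 32-fold lower number from compound 3 to compound 4 (1.50 log units; beyond the scatter) and a 35-fold lower number from compound 2 to compound 4 (1.55 log units; beyond the scatter). The configuration at that stereocentre has no readable effect on the number, with a 1.9-fold higher number from compound 1 to compound 4 (0.28 log units; within the scatter). Reading this pair as a direct test of that single stereocentre rests on one fact: the fact that compounds 1 and 4 differ only in the configuration as drawn

Still open, on these data alone, is whether the gain depends on the ring oxygen, which a piperidine ring or an open-chain amine at the same place would test. Also open, as far as these compounds go, is whether a longer chain on the ring amine would keep the low number seen with compound 1 and compound 4 in this assay.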